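This account rests on a few compounds, and the source may have more. Where it says the series, first, only, none or still open, it means among the compounds named here.

Compound 2 (`COc1ccc(/C=C/C(=O)c2cccc(Br)c2)cc1`) offers no number to start from: in a functional assay on MCF7 cells (Homo sapiens) for cytotoxicity, read by sulforhodamine B assay, with a stated time of 48 h (on this read-out higher numbers stand for weaker inhibition and lower numbers for stronger inhibition), compound 2 is recorded as "not determined" (no result reported) and so cannot be placed on the scale. For the measured compounds named here, the only measured relative is compound 1 (`COc1ccc(/C=C/C(=O)c2cccc(-c3ccc(F)cc3)c2)cc1`), and in this assay compound 1 gives 16400 nM as its result. Still unmeasured is compound 3 (`COc1ccc(/C=C/C(=O)c2cccc(-c3cccc(F)c3)c2)cc1`). The structural change puts a 3-fluorophenyl in place of the bromo on an aromatic carbon, meta to a large group (3-fluorophenyl in place of bromo on an aromatic carbon) and leaves the rest of the molecule untouched. Without a value for compound 2, this step has no measured size, and its direction cannot be read from the data. The best guide is compound 1 at 16400 nM and compound 3 is expected to differ from it by no more than the usual scatter. For compound 3 the estimated value is 16000 nM with an expected range from 7000 nM to 40000 nM in this test.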

Compound 3, half-maximal inhibitory concentration: 3080 nM
Compound 3: middle estimate off by 5.2-fold (0.72 log units), on the high side; the measured number lies below the stated range.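

Replacing the 4-fluorophenyl with a 3-fluorophenyl on the shared core gives, in this assay, a 5.3-fold lower number from compound 1 to compound 3 (0.73 log units; beyond the scatter). A lower number here means stronger inhibition, so moving the fluorine around the added ring changes the result by more than ordinary scatter, which a single measured compound could not show. Nothing shown here explains this shift.

As far as these compounds go, the steps from compound 2 cannot be read, so the effect of replacing the bromo with either fluorophenyl remains unknown. From the compounds shown here alone, it also remains open how a plain phenyl ring without fluorine, or an amine, would perform at this position, and so whether the fluorine helps at all or whether an aromatic ring is needed there.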